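Compound 3 to compound 4: swapping the pyridine

This account rests on a few compounds, and the source may have more. Where it says the series, first, only, none or still open, it means among the compounds named here.

Measured so far:
Compound 1 `CCCCc1nc(=O)c(S(=O)(=O)c2ccc(-c3ccc(F)nc3)cc2)c(O)n1-c1c(OC)cccc1OC`: 69%
Compound 2 `CCCCc1[nH]c(=O)c(S(=O)(=O)c2ccc(-c3ccc(F)cc3)cc2)c(O)c1-c1c(OC)cccc1OC`: "not determined" (no result reported)
Compound 3 `CCCCc1[nH]c(=O)c(S(=O)(=O)c2ccc(-c3ccncc3C)cc2)c(O)c1-c1c(OC)cccc1OC`: 39%

All numbers come from an ADME assay on microsomes from liver (Mus musculus) for metabolic stability, using NADPH, with a stated time of 10 min; on this read-out lower numbers stand for a less stable compound and higher numbers for a more stable compound. In this assay compound 1 gives 69%, whereas compound 3 gives 39%, the lower of the two numbers, with a gap that lies beyond the usual scatter. For the measured compounds named here, compounds 1 and 3 differ in more than one place, so their values show only that compound 3 sits lower. In this assay compound 2 is recorded as "not determined" (no result reported), so it gives no number to compare.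

Compound 4 `CCCCc1[nH]c(=O)c(S(=O)(=O)c2ccc(-c3cccnc3OC)cc2)c(O)c1-c1c(OC)cccc1OC` differs from compound 3 in a single place: 2-methoxypyridin-3-yl in place of 3-methylpyridin-4-yl on an aromatic carbon. Going by the values given here, no pair of measured compounds differs in only one place, so there is no comparable step to lean on, and the expectation rests on compound 3 alone. The step from compound 3 to compound 4 is expected to be small, a number 4 percentage points lower from compound 3 to compound 4 (within the scatter), not beyond the scatter in either direction. Compound 4 is therefore estimated at 35%, with a range from 15% to 60%.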

Compound 4, percent of the compound remaining: 24%
For compound 4 the middle estimate is 11 percentage points above the measured one; low and high end bracket the measured number.
By their numbers in this assay, from the lowest: compound 4; then compound 3; then compound 1.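

In this assay the change from 3-methylpyridin-4-yl to 2-methoxypyridin-3-yl gives a number 15 percentage points lower from compound 3 to compound 4 (beyond the scatter) and is the only step shown that alters one place alone, an aromatic carbon para to a large group. It shows that the read-out depends on which substituted pyridine sits at this position, even though both groups contain one six-membered aromatic ring with 1 hetero atom. No measured information here explains the step.

This change moves the ring nitrogen and the point of attachment and also replaces methyl with methoxy, so it remains open which of these differences accounts for the step. As far as these compounds go, how a different kind of group, such as an amine or a carboxylic acid, would read at this aromatic carbon also remains open.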